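From an aryl to a benzyl arm on the amide carbon

The source may hold more compounds than are shown below. What is called first, only, known or untested is meant among the compounds shown, and "the series" means these compounds.

Compound 1 `CC1CCN(c2nc(C(F)(F)F)ccc2CNC(=O)C(c2ccc(NS(C)(=O)=O)c(F)c2)C2CCCC2)CC1` and compound 2 `CS(=O)(=O)Nc1ccc(C(C(=O)NCc2ccc(C(F)(F)F)nc2SC2CCCCC2)c2cccc(F)c2)cc1F` share an amide core and a sulfonamide-bearing ring. In an assay on CHO cells for antagonist activity at transient receptor potential cation channel subfamily V member 1 (Homo sapiens), read by FLIPR (on this read-out higher numbers stand for weaker inhibition and lower numbers for stronger inhibition), compound 1 gives 88.7 nM, and compound 2 gives 48.7 nM, the lower of the two numbers, though the gap between them lies within the scatter of repeated measurements. Compound 3 `CS(=O)(=O)Nc1ccc(C(Cc2ccc(F)cc2)C(=O)NCc2ccc(C(F)(F)F)nc2SC2CCCCC2)cc1F` has not yet been measured. It differs from compound 2 by 4-fluorobenzyl in place of 3-fluorophenyl on a saturated chain carbon bound to an aromatic carbon and a carbonyl carbon. Among the compounds with values here, no measured pair shows this kind of change, so the direction is open; a modest shift, perhaps slightly weaker, is expected, with a 2.3-fold higher number from compound 2 to compound 3 (0.35 log units; beyond the scatter). Compound 3 is estimated at 110 nM, between 30 nM and 400 nM.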

Compound 3, inhibition constant: "active" (no number reported)
For compound 3 the study gives words and no number; there is nothing to compare the estimate with.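

Within the data shown here, compound 3 is reported only as active, without a number, so no step from compound 2 to compound 3 can be read. From the compounds shown here alone, how 4-fluorobenzyl in place of 3-fluorophenyl shifts inhibition stays open. No evidence bears on this result.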